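A few compounds are considered here, and "the series" means these few. Any claim that something is new, unique, unknown or untested is made for them only; others in the source may bear on it.

In a functional assay on MDA-MB-231 cells (Homo sapiens) for cytotoxicity, read by MTT assay, with a stated time of 72 h (a higher number here means a weaker inhibitor, a lower number a stronger inhibitor), compound 1 `O=C1c2c[n+]([O-])c3ccccc3c2C(=O)c2c1c1ccccc1n2Cc1cn(CC(O)CO)nn1` gives 1290 nM and compound 2 `CN(C)CCCCn1c2c(c3ccccc31)C(=O)c1c[n+]([O-])c3ccccc3c1C2=O` gives 350 nM as the lower of the two numbers. The change to compound 3 `O=C1c2c[n+]([O-])c3ccccc3c2C(=O)c2c1c1ccccc1n2CCCN1CCC(O)CC1` is 4-hydroxypiperidin-1-yl in place of (dimethylamino)methyl on a saturated chain carbon, three bonds along the chain from an aromatic nitrogen and leaves the shared core untouched. It puts 4-hydroxypiperidin-1-yl in place of (dimethylamino)methyl on a saturated chain carbon, three bonds along the chain from an aromatic nitrogen. For the measured compounds named here, the one measured step that bears on this is a 3.7-fold lower number from compound 1 to compound 2 (0.57 log units; beyond the scatter) and it also altered what the chain carries. Compound 1, with its 1-(2,3-dihydroxypropyl)-1H-1,2,3-triazol-4-yl group, holds the higher number at 1290 nM and likewise bears hydroxy groups, so a modest move upward is expected, though one step is a thin guide. The expected change is a 1.7-fold higher number from compound 2 to compound 3 (0.23 log units; within the scatter) on this estimate. For this assay the expected value of compound 3 is 600 nM with 220 nM to 1500 nM as the estimated range.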

Compound 3, half-maximal inhibitory concentration: 280 nM
The estimate for compound 3 lay 2.1-fold (0.33 log units) above the measured number, within the range that was stated.
By their numbers in this assay, from the lowest: compounds 3 and 2 (each within the scatter of the next); then compound 1.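

In this assay, the step to the larger 4-hydroxypiperidin-1-yl group, on a saturated chain carbon three bonds along the chain from an aromatic nitrogen, gives a 1.3-fold lower number from compound 2 to compound 3 (0.10 log units; within the scatter) and so does not separate the two compounds. This position therefore accepts a six-membered ring bearing a hydroxy group in place of (dimethylamino)methyl, and the step of a 4.6-fold lower number from compound 1 to compound 3 (0.66 log units; beyond the scatter) shows that a hydroxy group on the side chain does not by itself go with the higher number of compound 1. Nothing available explains these numbers.

On these data alone, the contribution of the hydroxy group itself remains open, and a plain piperidin-1-yl group on the same chain would isolate it. Also open, as far as these compounds go, is how the number responds to a morpholin-4-yl group, a carboxylic acid or a longer chain here.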